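Chloro to Trifluoromethyl on the Benzylsulfanyl Arm

This account rests on a few compounds, and the source may have more. Where it says the series, first, only, none or still open, it means among the compounds named here.

Within the data shown here, compound 2 `Cc1cc(Nc2ccc(C(=O)/C=C/c3cccc(Br)n3)cc2)n2nc(SCc3ccc(Cl)cc3)nc2n1` gives 90.2% in a functional assay on MGC-803 cells (Homo sapiens) for inhibition, read by sulforhodamine B assay, with a stated time of 72 h, tested at 10 uM (a lower number here means less inhibition, a higher number more inhibition at the concentration tested (going by the name of the read-out)), the highest of the three numbers known. Compound 3 `Cc1nc2nc(SCc3ccc(Cl)cc3)nn2c(Nc2ccc(C(=O)/C=C/c3cccc(Br)n3)cc2)c1C` gives 72.5%, and compound 1 `O=C(/C=C/c1cccc(Br)n1)c1ccc(Nc2cc(-c3ccccc3)nc3nc(SCc4ccccc4)nn23)cc1` gives 38.3%. Among the measured compounds shown here, the only step with a single change, a number 17.7 percentage points lower from compound 2 to compound 3 (beyond the scatter), is methyl in place of hydrogen on an aromatic carbon, a site untouched here. Compound 4 `Cc1cc(Nc2ccc(C(=O)/C=C/c3cccc(Br)n3)cc2)n2nc(SCc3ccc(C(F)(F)F)cc3)nc2n1` differs from compound 2 by trifluoromethyl in place of chloro on an aromatic carbon. For the measured compounds named here, no measured step alters this group, so no direction can be read from the data; compound 1 has an unsubstituted benzyl but differs at a second site too. Compound 4 is therefore expected to stay near compound 2, with an estimate of 82%, between 58% and 96%. The expected step of a number 8.2 percentage points lower from compound 2 to compound 4 (within the scatter) is within the scatter.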

Compound 4, a percentage reported as inhibition, at one concentration (the size of the read-out at that concentration, not a potency): 96.6%
Compound 4: middle estimate off by 14.6 percentage points, on the low side, and the stated range ends below it.
By their numbers in this assay, from the lowest: compound 1; then compound 3; then compounds 2 and 4 (each within the scatter of the next).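

In this assay the first step read at this position, trifluoromethyl in place of chloro on the benzylsulfanyl arm, is a number 6.4 percentage points higher from compound 2 to compound 4 (within the scatter), so the two groups cannot be told apart at this place. On the core of compound 2, the arm thus carries either group with no change beyond the scatter. Nothing available accounts for this result. Still open, as far as these compounds go, is what an amine or a methoxy group at this place would give, and whether the same exchange reads alike on the core of compound 3.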